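Trifluoromethoxy for Trifluoromethyl on the Core of Compound 1

A few compounds are considered here, and "the series" means these few. Any claim that something is new, unique, unknown or untested is made for them only; others in the source may bear on it.

Measured compounds:
compound 1 `Oc1cccc(-c2cc(-c3ccccc3C(F)(F)F)cc(-c3ccccc3O)n2)c1`: 7250 nM
compound 2 `Oc1ccc(-c2cc(-c3ccccc3C(F)(F)F)cc(-c3ccccc3O)n2)cc1`: 6690 nM
compound 3 `Oc1ccc(-c2cc(-c3ccccc3C(F)(F)F)cc(-c3cccc(O)c3)n2)cc1`: 2750 nM

In a functional assay on DU-145 cells (Homo sapiens) for inhibition (on this read-out higher numbers stand for weaker inhibition and lower numbers for stronger inhibition), compound 1 gives the highest of the three numbers. The step of a 1.1-fold lower number from compound 1 to compound 2 (0.03 log units; within the scatter) lies within the scatter, whereas a 2.6-fold lower number from compound 1 to compound 3 (0.42 log units; beyond the scatter) and a 2.4-fold lower number from compound 2 to compound 3 (0.39 log units; beyond the scatter) are modest but beyond it. Compound 4 `Oc1cccc(-c2cc(-c3ccccc3OC(F)(F)F)cc(-c3ccccc3O)n2)c1` differs from compound 1 by trifluoromethoxy in place of trifluoromethyl on an aromatic carbon. Among the compounds with values here, all three measured steps concern the hydroxyphenyl groups alone; no measured pair sets trifluoromethoxy against trifluoromethyl, so none of them bears on this change. With nothing to anchor a direction, compound 4 is expected to show the step of no change at the digits printed from compound 1 to compound 4 (within the scatter), which is not expected to exceed the scatter. Compound 4 is therefore estimated at 7250 nM in this assay, within a wide range of 2400 nM to 22000 nM, the width reflecting the absence of any relevant measured step.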

Compound 4, half-maximal inhibitory concentration: > 50000 nM
Compound 4: only a limit was reported (the forecaster's own chance of this, stated with the estimate: 5%); middle value at least 6.8-fold (0.83 log units) away from the limit.
By their numbers in this assay, from the lowest: compound 3; then compounds 2 and 1 (each within the scatter of the next). At a limit, above all of these: compound 4.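

Compound 4 reads > 50000 nM in this assay, which is a limit of the assay and not a number: the limit of > 50000 nM in this assay, at which 1 of the 4 values shown sits. The hydroxyphenyl steps never touched the position ortho to a large group, and this place proves sensitive to trifluoromethoxy in place of trifluoromethyl, with an at least 6.8-fold higher number from compound 1 to compound 4 (0.83 log units; beyond the scatter), a loss of inhibition.

As far as these compounds go, the true size of this step stays open, as does whether the same change would act alike with the hydroxyphenyl arrangement of compound 3. Also open, from the compounds shown here alone, is how a methyl, a chlorine or an amine would fare at this place.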